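A few compounds are considered here, and "the series" means these few. Any claim that something is new, unique, unknown or untested is made for them only; others in the source may bear on it.

The measured compounds:
compound 1, `O=C(Nc1ccccc1O)C1CCc2ccccc2N1C(=O)c1ccc(Cl)cc1`, 13400 nM
compound 2, `O=C(Nc1ccc(C(F)(F)F)cc1)C1CCc2ccccc2N1`, 18600 nM
compound 3, `CCCC(=O)N1c2ccccc2CCC1C(=O)Nc1ccccc1C(F)(F)F`, > 70000 nM

In a functional assay on NUGC-3 cells (Homo sapiens) for cytotoxicity, read by sulforhodamine B assay, with a stated time of 72 h (on this read-out higher numbers stand for weaker inhibition of growth and lower numbers for stronger inhibition of growth), compound 1 gives 13400 nM and compound 2 gives 18600 nM. For compound 3 this assay reports only a limit, > 70000 nM, which is not a number, and compound 3 therefore sits at the limit of > 70000 nM in this assay, at which 1 of the 3 values shown sits. Compound 4, `O=C(Nc1ccccc1C(F)(F)F)C1CCc2ccccc2N1C(=O)c1cccc(Cl)c1`, differs from compound 3 in one place: 3-chlorophenyl in place of propyl on a carbonyl carbon. For the measured compounds named here, no step between two measured compounds covers this change, so its size can only be judged from the values shown. Compound 1, whose ring nitrogen carries a chlorophenyl carbonyl group, gives 13400 nM in this assay, and compound 2, which carries nothing on that nitrogen, gives 18600 nM. On that basis compound 4 is expected to give a number rather than a limit, estimated at 20000 nM with a range from 6000 nM to 70000 nM. The expected step is then an at least 3.5-fold lower number from compound 3 to compound 4 (0.54 log units; beyond the scatter), an estimate from a limit and not a measured change.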

Compound 4, concentration for 50% growth inhibition: 754 nM
Compound 4: the middle estimate sits 27-fold (1.42 log units) above what was measured; the measured number lies below the stated range.
By their numbers in this assay, from the lowest: compound 4; then compounds 1 and 2 (each within the scatter of the next). At a limit, above all of these: compound 3.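

In this assay, for the compounds shown here, this is the first step in the set that isolates a single place: with the rest of the molecule unchanged, 3-chlorophenyl in place of propyl on a carbonyl carbon goes with an at least 92-fold lower number from compound 3 to compound 4 (1.96 log units; beyond the scatter). Growth inhibition therefore depends strongly on what this carbonyl carries, and the change adds one six-membered aromatic ring of carbon only and a chlorine, with no hydrogen-bond donors or acceptors on either side. Compound 3 stands at a limit, so the size of this step is a bound: the limit of > 70000 nM in this assay, at which 1 of the 4 values shown sits.

The compounds shown do not tell whether the ring alone or the ring with its chlorine goes with this step, and a plain phenyl on the same carbonyl would separate the two. Nor do they say how a cyclohexyl group or a pyridine ring in that place would read in this assay.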